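The source may report more compounds than this note shows. Statements on the series, on what has been measured and on what is new or still open speak of the compounds shown alone.

Compound 1 `CCCCCCCCCCc1ccccc1C(SCCC(=O)O)SCCC(=O)O` carries a decyl chain on the aromatic ring of the shared core, and in an assay on membranes from lung (Cavia porcellus) for binding affinity to cysteinyl leukotriene receptor (Homo sapiens) (on this read-out higher numbers stand for weaker inhibition and lower numbers for stronger inhibition), compound 1 gives 1180 nM. This is the highest of the two numbers at hand. Its nearest neighbour is compound 2 `CCCCCCCCCC/C=C/c1ccccc1C(SCCC(=O)O)SCCC(=O)O`, which differs in the unsaturated link between the chain and the ring; in this assay compound 2 gives 491 nM, a lower number that lies beyond the usual scatter.

Compound 3 `CCCCc1ccc(CCCCc2ccccc2C(SCCC(=O)O)SCCC(=O)O)cc1` has not been measured. It differs from compound 1 in one place: 4-butylphenyl in place of hexyl on a saturated chain carbon, four bonds along the chain from an aromatic carbon. Going by the values given here, no pair of measured compounds shows this kind of change, so the size of the step has to be guessed. Among the compounds with values here, the only measured step, from compound 1 to compound 2, shows that a change in the chain can move the number by more than the scatter, but in which direction a ring at the end of the chain would push it cannot be read from the data. The estimate for compound 3 in this assay is 700 nM, within a range of 200 nM to 2500 nM, which would mean an expected step of a 1.7-fold lower number from compound 1 to compound 3 (0.23 log units; within the scatter) from compound 1 that is probably small.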

Compound 3, inhibition constant: 4230 nM
The estimate for compound 3 lay 6.0-fold (0.78 log units) below the measured number; measured number outside the range, above it.
By their numbers in this assay, from the lowest: compound 2; then compound 1; then compound 3.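

In this assay, 4-butylphenyl in place of hexyl on a saturated chain carbon, four bonds along the chain from an aromatic carbon, gives a 3.6-fold higher number from compound 1 to compound 3 (0.55 log units; beyond the scatter), which on this read-out means weaker inhibition. The earlier pair had shown only a fall in the number, with compound 1 at 1180 nM and compound 2 at 491 nM, so this result is the first sign that a change in the chain can also raise it, and that a ring-bearing chain end at this position does not match the plain chain of compound 1. Nothing at hand accounts for this rise in the number.

The compounds shown leave open whether the rise goes with the phenyl ring itself or with the butyl group it carries, a question that an unsubstituted phenyl at the same place would address. They also leave open how a longer unbranched chain would compare with the decyl chain of compound 1, and whether an amine or a carboxylic acid at the chain end would move the number in either direction.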